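Trading a halogenated aniline ring for a methoxy aniline

The source may report more compounds than this note shows. Statements on the series, on what has been measured and on what is new or still open speak of the compounds shown alone.

Among the measured compounds shown here, compound 3 `COc1cc2ncnc(Nc3ccc(F)c(Br)c3)c2cc1OCCCCC(=O)Nc1ccc(S(N)(=O)=O)cc1` gives 8020 nM in a functional assay on A-431 cells (Homo sapiens) for antiproliferative activity, read by MTT assay, with a stated time of 72 h (on this read-out lower numbers stand for stronger inhibition and higher numbers for weaker inhibition), the second highest of the three numbers known here: compound 1 `COc1cc2ncnc(Nc3ccc(Cl)c(C(F)(F)F)c3)c2cc1OCCCCC(=O)Nc1ccc(S(N)(=O)=O)cc1` gives 3910 nM and compound 2 `COc1ccc(Nc2ncnc3cc(OC)c(OCCCCC(=O)Nc4ccc(S(N)(=O)=O)cc4)cc23)cc1` gives 14700 nM. Among the measured steps, a 2.1-fold higher number from compound 1 to compound 3 (0.31 log units; beyond the scatter) and a 3.8-fold higher number from compound 1 to compound 2 (0.58 log units; beyond the scatter), whereas a 1.8-fold lower number from compound 2 to compound 3 (0.26 log units; within the scatter). Compound 4 `COc1ccccc1Nc1ncnc2cc(OC)c(OCCCCC(=O)Nc3ccc(S(N)(=O)=O)cc3)cc12` differs from compound 3 by 2-methoxyphenyl in place of 3-bromo-4-fluorophenyl on a nitrogen on an aromatic ring. For the measured compounds named here, the closest precedent is compound 2, the only other methoxyphenyl bearer, and its number sits within the scatter of compound 3, so any movement in this assay is expected to be small and, if anything, upward. Compound 4 is therefore expected to show a 1.6-fold higher number from compound 3 to compound 4 (0.21 log units; within the scatter) in this assay. The value of compound 4 is estimated at 13000 nM, within a range from 5500 nM to 32000 nM.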

Compound 4, half-maximal inhibitory concentration: 24200 nM
For compound 4 the middle estimate is 1.9-fold (0.27 log units) below the measured one; the measured number falls inside the stated range.
By their numbers in this assay, from the lowest: compound 1; then compounds 3, 2 and 4 (each within the scatter of the next, the first and the last beyond it).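

In this assay, with 2-methoxyphenyl on the nitrogen the separation from both halogenated rings lies beyond the scatter, a 3.0-fold higher number from compound 3 to compound 4 (0.48 log units; beyond the scatter) and a 6.2-fold higher number from compound 1 to compound 4 (0.79 log units; beyond the scatter), whereas compound 2 stayed within the scatter of compound 3. The two methoxyphenyl rings themselves cannot be told apart, a 1.6-fold higher number from compound 2 to compound 4 (0.22 log units; within the scatter). Nothing given here accounts for these differences.

The compounds shown leave open whether an unsubstituted phenyl ring on this nitrogen would group with the halogenated rings or with the methoxyphenyl rings, and whether a longer chain would shift these numbers.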